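The compounds below may be only part of what the source reports. "The series", "measured", "known", "first", "only" and "open" are said of these compounds alone.

Measured compounds:
compound 1, `COC1=CC(=O)c2c(c(CO)c(C3CC3)n2C)C1=O` — in a functional assay on V79-379A cells (Cricetulus griseus) for cytotoxicity, read by MTT assay, in the presence of a further agent that is not named here (a higher number here means a weaker inhibitor, a lower number a stronger inhibitor), compound 1 gives 540000 nM
compound 2, `COC1=CC(=O)c2c(c(COC(=O)c3ccc(F)cc3)cn2C)C1=O` — in this assay compound 2 gives 700 nM
compound 3, `COC1=CC(=O)c2c(c(COC(=O)c3ccccc3)cn2C)C1=O` — in this assay compound 3 gives 1400 nM

Compound 3 has the second highest of the three numbers. Its nearest neighbour is compound 2, and the step of a 2.0-fold higher number from compound 2 to compound 3 (0.30 log units; within the scatter) lies within the scatter, so these two read as equivalent. For the measured compounds named here, compound 1 stands far from compound 3; the two values differ by much more than the scatter, but compound 1 differs from compound 3 in two places at once, so no single step links them.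

Compound 4, `COC1=CC(=O)c2c(c(COC(=O)c3ccccc3)c(C3CC3)n2C)C1=O`, differs from compound 3 by cyclopropyl in place of hydrogen on an aromatic carbon. Going by the values given here, no measured pair isolates this change. Among the compounds with values here, compound 1 is the only compound bearing a cyclopropyl, and it carries a hydroxymethyl where compound 3 carries the benzoate ester, so its high number cannot be assigned to the cyclopropyl alone. Given compound 3 at 1400 nM and the absence of a comparable step, compound 4 is expected near compound 3 with a lean toward a higher number, the estimated step being a 2.1-fold higher number from compound 3 to compound 4 (0.33 log units; beyond the scatter). Compound 4 is therefore estimated at 3000 nM, with a range from 700 nM to 20000 nM.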

Compound 4, half-maximal inhibitory concentration: 198000 nM
The estimate for compound 4 lay 66-fold (1.82 log units) below the measured number, and the stated range ends below it.
By their numbers in this assay, from the lowest: compounds 2 and 3 (each within the scatter of the next); then compound 4; then compound 1.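

In this assay, the step of a 140-fold higher number from compound 3 to compound 4 (2.15 log units; beyond the scatter) isolates the change at this position: cyclopropyl in place of hydrogen on the aromatic carbon next to the ring nitrogen. The position is therefore far from indifferent to substitution, at least with the benzoate ester present, and the cyclopropyl alone carries a large rise in the number. With the cyclopropyl held fixed, the step of a 2.7-fold lower number from compound 1 to compound 4 (0.44 log units; beyond the scatter) shows that benzoyl in place of hydrogen on the oxygen brings only a modest change, so in this pair the ester does not restore a low number. No measurement here gives a reason for the size of either step.

As far as these compounds go, it remains open whether the rise belongs to cyclopropyl in particular or would also follow from a smaller or different group at this position, such as an ethyl or an aminomethyl group. From the compounds shown here alone, the effect of benzoyl on the hydroxymethyl without a cyclopropyl, and the size of the cyclopropyl step with the 4-fluorobenzoate ester of compound 2, also remain unknown.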